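Smaller groups on the aromatic nitrogen of the shared core

The source may hold more compounds than are shown below. What is called first, only, known or untested is meant among the compounds shown, and "the series" means these compounds.

Compound 1 `O=C(O)c1cc(-c2cccc(COc3ccc4c(=O)n(C5CCC5)sc4c3)c2)ccc1Cl`: 580 nM
Compound 2 `O=C(O)c1cc(-c2cccc(COc3ccc4c(=O)n(C5CC5)sc4c3)c2)ccc1Cl`: 130 nM
Compound 3 `O=C1c2ccc(OCc3cccc(-c4ccc(C(F)(F)F)cc4F)c3)cc2CN1C1CCCC1`: > 5000 nM

In an assay on HEK293 cells for positive allosteric modulation of metabotropic glutamate receptor 2 (Rattus norvegicus), read by thallium flux (a lower number here means that less compound is needed, a higher number that more compound is needed for the effect), compound 2 gives the lowest of the two numbers; compound 1 sits higher by a 4.5-fold lower number from compound 1 to compound 2 (0.65 log units; beyond the scatter). Compound 3 gives only a limit, not a number: the limit of > 5000 nM in this assay, at which 1 of the 3 values shown sits.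

Compound 4 `Cn1sc2cc(OCc3cccc(-c4ccc(Cl)c(C(=O)O)c4)c3)ccc2c1=O` differs from compound 2 by methyl in place of cyclopropyl on an aromatic nitrogen. Among the measured compounds shown here, the only measured step at this nitrogen is the one from compound 1 to compound 2, which was modest and beyond the scatter; it concerns a different pair of groups, so it is a loose guide only. With one step to lean on, the expectation for compound 4 is a number near that of compound 2, with a wide band either way, estimated as a 1.2-fold higher number from compound 2 to compound 4 (0.06 log units; within the scatter). The estimate for compound 4 is 150 nM, within 40 nM to 600 nM.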

Compound 4, half-maximal effective concentration: 640 nM
For compound 4 the middle estimate is 4.3-fold (0.63 log units) below the measured one, outside the stated range (above it).
By their numbers in this assay, from the lowest: compound 2; then compounds 1 and 4 (each within the scatter of the next). At a limit, above all of these: compound 3.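

Replacing cyclopropyl with methyl on the aromatic nitrogen gives a 4.9-fold higher number from compound 2 to compound 4 (0.69 log units; beyond the scatter) and so loses the gain seen with cyclopropyl. Methyl and cyclobutyl show a 1.1-fold higher number from compound 1 to compound 4 (0.04 log units; within the scatter), so the number does not follow group size in one direction: among these three groups, only cyclopropyl stands apart. Nothing shown here gives a reason for this.

Still open, going by these compounds, is whether cyclopropyl is unique at this nitrogen or whether an isopropyl or ethyl group would match it. Also open, on these data alone, is whether a cyclopropane ring carrying an amine would keep the number of compound 2.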